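Fluoro for Chloro on the Aryl Ring

The source may report more compounds than this note shows. Statements on the series, on what has been measured and on what is new or still open speak of the compounds shown alone.

compound 1 `Nc1ccccc1NC(=O)c1ccc(CSC(=S)N2CCN(C(c3ccccc3)c3ccccc3)CC2)cc1`: 9.8%
compound 2 `Nc1ccccc1NC(=O)c1ccc(CSC(=S)N2CCN(c3ccc(Cl)cc3)CC2)cc1`: 15%

In a functional assay on MGC-803 cells (Homo sapiens) for antiproliferative activity, read by CCK-8 assay, with a stated time of 72 h, tested at 2 uM (a higher number here means a stronger effect of the compound at the concentration tested, a lower number a weaker effect), compound 1 gives 9.8%, and compound 2 gives 15%. Compound 2 holds the higher of these two numbers, but its gap to compound 1 lies within the scatter, so the two cannot be told apart. Compound 3 `Nc1ccccc1NC(=O)c1ccc(CSC(=S)N2CCN(c3ccc(F)cc3)CC2)cc1` differs from compound 2 in one place: fluoro in place of chloro on an aromatic carbon. Within the data shown here, no measured pair shows what this change does here, so the step is expected to stay small: a number 1 percentage points lower from compound 2 to compound 3 (within the scatter), with no direction beyond the scatter. Compound 3 is expected to give about 14%, within 5% to 24%.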

Compound 3, a percentage reported as inhibition, at one concentration (the size of the read-out at that concentration, not a potency): 18.8%
Estimate against measurement, compound 3: 4.8 percentage points below; the measured number falls inside the stated range.
By their numbers in this assay, from the lowest: compounds 1, 2 and 3 (each within the scatter of the next).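

In this assay, among these compounds, fluoro in place of chloro on an aromatic carbon, para to a large group, gives a number 3.8 percentage points higher from compound 2 to compound 3 (within the scatter) and so offers the first direct reading of a change at this place. At this single concentration, the 4-chlorophenyl and 4-fluorophenyl compounds cannot be told apart. Nothing available bears on the reason for this result. The compounds shown leave open whether an amine, a methoxy group or a carboxylic acid on this carbon would move the number beyond the scatter. They also leave open what a second substituent on this ring would do.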